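Tail-group replacement on the acid series

A few compounds are considered here, and "the series" means these few. Any claim that something is new, unique, unknown or untested is made for them only; others in the source may bear on it.

Measured in an assay for inhibition of inositol hexakisphosphate kinase 2 (Homo sapiens), read by colorimetric assay, coupled enzyme assay and malachite green, with a stated time of 120 min, in the presence of a further agent that is not named here; on this read-out higher numbers stand for weaker inhibition and lower numbers for stronger inhibition:
compound 1 `O=C(O)c1ccc2noc(-c3ccc(Cc4ccccc4)cc3)c2c1`: 65 nM
compound 2 `O=C(O)c1ccc2noc(-c3ccc(Oc4ccccc4)cc3)c2c1`: 280 nM

Going by the values given here, compound 2 gives the highest of the two numbers so far; its nearest neighbour is compound 1, and the step of a 4.3-fold higher number from compound 1 to compound 2 (0.63 log units; beyond the scatter) is the only measured one in the set. Compound 3 `CC(C)NC(=O)c1ccc(-c2onc3ccc(C(=O)O)cc23)cc1` differs from compound 2 by isopropylcarbamoyl in place of phenoxy on an aromatic carbon. Among the compounds with values here, no measured step involves an isopropylcarbamoyl group, so the only guide is the single exchange on an aromatic carbon captured in a 4.3-fold higher number from compound 1 to compound 2 (0.63 log units; beyond the scatter), which was modest and ran toward a higher number. A step of comparable size is therefore expected in this assay for the present exchange, with the direction left open and a higher number slightly favoured. Compound 3 is accordingly expected to give 500 nM, with a range of 100 nM to 2500 nM. For compound 3 this amounts to an expected step of a 1.8-fold higher number from compound 2 to compound 3 (0.25 log units; within the scatter).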

Compound 3, half-maximal inhibitory concentration: 350 nM
Compound 3: middle estimate off by 1.4-fold (0.15 log units), on the high side; the measured number falls inside the stated range.
By their numbers in this assay, from the lowest: compound 1; then compounds 2 and 3 (each within the scatter of the next).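

In this assay, at the aromatic carbon para to a large group, isopropylcarbamoyl, which has no ring and carries a hydrogen-bond donor, cannot be told apart from phenoxy (a 1.3-fold higher number from compound 2 to compound 3 (0.10 log units; within the scatter)). An aromatic ring in the tail is therefore not needed to reach the level of compound 2 among these compounds. Benzyl remains separate from both tails, as the exchange for isopropylcarbamoyl also shows (a 5.4-fold higher number from compound 1 to compound 3 (0.73 log units; beyond the scatter)), and no supporting data bear on why these tails compare as they do.

Going by these compounds, whether the amide hydrogen contributes to the reading of compound 3 remains open, as does the role of the branched isopropyl group compared with a straight propyl chain. On these data alone, it is also open whether a benzylamine or a carboxylic acid at this position would read nearer compound 1 or compound 3.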